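Removing the acyl piperazine from an anilide: cytotoxicity outlook

A few compounds are considered here, and "the series" means these few. Any claim that something is new, unique, unknown or untested is made for them only; others in the source may bear on it.

Measured so far:
- compound 1 `CC(=O)Nc1ccc(-c2nc3cc(C(F)(F)F)ccc3n2C2CCCCC2)cc1`: 24000 nM
- compound 2 `CN1CCN(CC(=O)Nc2ccc(-c3nc4cc(C(F)(F)F)ccc4n3C)cc2)CC1`: 22000 nM
- compound 3 `Cn1c(-c2ccc(NC(=O)CN3CCN(c4ccccc4)CC3)cc2)nc2cc(C(F)(F)F)ccc21`: 1500 nM

These three compounds share one core and differ only in what hangs on the nitrogen of the aniline ring. In an ADME assay on MT4 cells (Homo sapiens) for cytotoxicity, read by MTT assay, with a stated time of 96 h (a lower number here means that less compound is tolerated, a higher number that more compound is tolerated), compound 2 gives 22000 nM and stands second highest of the three; compound 1 sits within the scatter of it, while compound 3 lies well apart, with a 15-fold lower number from compound 2 to compound 3 (1.17 log units; beyond the scatter).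

Compound 4 `Cn1c(-c2ccc(N)cc2)nc2cc(C(F)(F)F)ccc21` is not yet measured. It differs from compound 2 in one place: hydrogen in place of ((4-methylpiperazin-1-yl)methyl)carbonyl on a nitrogen on an aromatic ring.

Going by the values given here, only one measured step exists, and it concerns a change inside the group that is now removed altogether, so it does not bear directly on this step. Compound 1 and compound 2 show that two different groups on that nitrogen give numbers within the scatter of each other, which hints that this position is not decisive. Compound 4 is therefore expected to give 20000 nM, between 7000 nM and 60000 nM, a step of a 1.1-fold lower number from compound 2 to compound 4 (0.04 log units; within the scatter) that is expected to stay within the scatter.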

Compound 4, half-maximal cytotoxic concentration: 20000 nM
Estimate against measurement, compound 4: no gap at the digits printed; the range from low to high includes it.
By their numbers in this assay, from the lowest: compound 3; then compounds 4, 2 and 1 (each within the scatter of the next).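

In this assay, taking off the whole ((4-methylpiperazin-1-yl)methyl)carbonyl group and leaving only hydrogen on the nitrogen on an aromatic ring gives a 1.1-fold lower number from compound 2 to compound 4 (0.04 log units; within the scatter) and so stays within the scatter. The earlier compounds shown here compared only one acylated nitrogen with another, whereas this result shows that the free amine and the acylated form of this nitrogen cannot be told apart here. Going by these compounds alone, the one step beyond the scatter remains a 15-fold lower number from compound 2 to compound 3 (1.17 log units; beyond the scatter) with phenyl in place of methyl on an amine nitrogen in a ring, and the new result does not alter that step.

As far as these compounds go, it remains open whether a sulfonamide, a urea or a longer chain on this nitrogen would also stay within the scatter, or whether a benzyl group on the piperazine would match the phenyl group. No measured evidence accompanies these numbers to explain them.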